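The source may hold more compounds than are shown below. What is called first, only, known or untested is meant among the compounds shown, and "the series" means these compounds.

Measured in a functional assay on MT4 cells (Homo sapiens) for inhibition; a higher number here means a weaker inhibitor, a lower number a stronger inhibitor:
- Compound 1 `COC(=O)c1[nH]c2ccc(Cl)cc2c1Sc1ccccc1`: 1500 nM
- Compound 2 `NC(=O)c1[nH]c2ccc(Cl)cc2c1Sc1ccccc1`: 200 nM
- Compound 3 `CN(C)C(=O)c1[nH]c2ccccc2c1Sc1ccccc1`: > 3000 nM, a limit and not a number

Compound 2, at 200 nM, holds the lower of the two actual numbers. Compound 4 `CNC(=O)c1[nH]c2ccc(Cl)cc2c1Sc1ccccc1` differs from compound 2 by methyl in place of hydrogen on an amide-type nitrogen. Going by the values given here, the only measured step, a 7.5-fold lower number from compound 1 to compound 2 (0.88 log units; beyond the scatter), changes the group on the same carbonyl carbon but does not test this substitution, so it bears on the change only indirectly. Compound 3, with its limit of > 3000 nM, also carries methyl on its amide-type nitrogen, but it differs from compound 2 in other places too. A modest move towards weaker inhibition is therefore expected in this assay, an estimated 2.5-fold higher number from compound 2 to compound 4 (0.40 log units; beyond the scatter). For compound 4 the estimated value is 500 nM, with an expected range from 150 nM to 2000 nM.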

Compound 4, concentration for 95% inhibition: 200 nM
Estimate against measurement, compound 4: 2.5-fold (0.40 log units) above, within the range that was stated.
By their numbers in this assay, from the lowest: compounds 2 and 4 (each within the scatter of the next); then compound 1. At a limit, above all of these: compound 3.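

In this assay, methyl on the amide-type nitrogen leaves the number in place, with no change at the digits printed from compound 2 to compound 4 (within the scatter). The advantage over methoxy on the carbonyl carbon therefore persists with methylamino, at a 7.5-fold lower number from compound 1 to compound 4 (0.88 log units; beyond the scatter). Nothing shown gives a cause for this tolerance.

For compound 3, > 3000 nM is a limit and not a number. From the compounds shown here alone, whether a longer chain such as ethyl, a second methyl on this nitrogen with the chloro group kept, or a cyclic amine such as pyrrolidine would be tolerated as well remains open.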